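Swapping the aryl group on the shared core

This account rests on a few compounds, and the source may have more. Where it says the series, first, only, none or still open, it means among the compounds named here.

Measured so far:
Compound 1, `N#CC1=C(N)N(c2ccc(S(N)(=O)=O)cc2)C2=C(C(=O)CCC2)C1c1ccc(O)cc1`: 95%
Compound 2, `N#CC1=C(N)N(c2ccc(S(N)(=O)=O)cc2)C2=C(C(=O)CCC2)C1c1c(O)ccc2ccccc12`: 0%

Both were tested in a functional assay on Ehrlich cells (Mus musculus) for antiproliferative activity, read by trypan blue exclusion, with a stated time of 2 h, tested at 25 ug/mL; on this read-out higher numbers stand for a stronger effect at the one concentration tested and lower numbers for a weaker effect. Among the measured compounds shown here, compound 2 stands lowest of the two numbers; its nearest neighbour is compound 1, and the only measured step, a number 95 percentage points lower from compound 1 to compound 2 (beyond the scatter), is large and well beyond the scatter. Compound 3, `N#CC1=C(N)N(c2ccc(S(N)(=O)=O)cc2)C2=C(C(=O)CCC2)C1c1cccs1`, has not yet been measured. It differs from compound 2 by thiophen-2-yl in place of 2-hydroxynaphthalen-1-yl on a saturated ring carbon.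

For the measured compounds named here, the one step that bears on this change is the step from compound 1 to compound 2, where the group on the same saturated ring carbon was exchanged and the read-out fell by almost the whole scale. Going by the values given here, that step shows that this position is sensitive to what sits on it, but it does not show what a thiophen-2-yl group does there; no measured compound carries a five-membered aromatic ring at this place. The direction for compound 3 is therefore uncertain, though a group of a size closer to the 4-hydroxyphenyl of compound 1 than to the 2-hydroxynaphthalen-1-yl of compound 2 might recover much of the lost activity. A large upward step, a number 55 percentage points higher from compound 2 to compound 3 (beyond the scatter), is expected. Compound 3 is estimated at 55%, within 10% to 95%.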

Compound 3, a percentage reported as activity, at one concentration (the size of the read-out at that concentration, not a potency): 80%
Compound 3: the middle estimate sits 25 percentage points below what was measured; the measured number falls inside the stated range.
By their numbers in this assay, from the lowest: compound 2; then compound 3; then compound 1.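

In this assay, thiophen-2-yl in place of 2-hydroxynaphthalen-1-yl gives a number 80 percentage points higher from compound 2 to compound 3 (beyond the scatter), so the fall seen with compound 2 is not a general feature of changing the group on this saturated ring carbon. Thiophen-2-yl in place of 4-hydroxyphenyl gives only a number 15 percentage points lower from compound 1 to compound 3 (beyond the scatter), which shows that a high read-out here needs neither a six-membered aromatic ring nor a hydrogen-bond donor on this group, even though compound 1 stays ahead of compound 3. No measurement at hand explains why these three groups give such different read-outs.

The compounds shown cannot tell whether the collapse with compound 2 goes with its second aromatic ring, with the place of its hydroxyl, or with both, since these change together; a naphthalen-1-yl group without the hydroxyl and a 2-hydroxyphenyl group would pull them apart. On these data alone, it also remains open whether the sulfur of thiophen-2-yl matters, which a furan-2-yl or a plain phenyl group at the same carbon would test, and each read-out here is the size of an effect at one concentration, not a potency.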